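From hydrogen to chloro: estimating compound 3

The source may report more compounds than this note shows. Statements on the series, on what has been measured and on what is new or still open speak of the compounds shown alone.

- compound 1 `CCCCC#Cc1c(C)[nH]c2ccc(OC)cc2c1=O`: 5.25
- compound 2 `CCCCC#Cc1c(C)[nH]c2ccccc2c1=O`: 5.44

In a physicochemical assay for lipophilicity, at pH 7.4 (a higher number here means a more lipophilic compound, a lower number a more polar compound), compound 2 gives 5.44, level with compound 1 within the scatter. The next step leads to compound 3 `CCCCC#Cc1c(C)[nH]c2ccc(Cl)cc2c1=O`, which has chloro in place of hydrogen on an aromatic carbon. For the measured compounds named here, only one measured step bears on this change: a number 0.19 log units higher from compound 1 to compound 2 (within the scatter), where hydrogen takes the place of methoxy on an aromatic carbon. Going by the values given here, that step involves a different group, and no chloro compound has been measured yet, so it is only a weak guide. A small rise is expected, an estimated a number 0.36 log units higher from compound 2 to compound 3 (beyond the scatter). For compound 3 the estimated value in this assay is 5.8, with an expected range of 5.4 to 6.2.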

Compound 3, distribution coefficient: 2.98
Compound 3: the middle estimate sits 2.82 log units above what was measured, outside the stated range (below it).
By their numbers in this assay, from the lowest: compound 3; then compounds 1 and 2 (each within the scatter of the next).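

In this assay chloro brings a number 2.46 log units lower from compound 2 to compound 3 (beyond the scatter) and a number 2.27 log units lower from compound 1 to compound 3 (beyond the scatter) while the earlier swap of methoxy for hydrogen stayed within the scatter, so this position on the shared core is not indifferent to what sits there. Hydrogen and methoxy alone gave no sign of such a large change at this aromatic carbon. Nothing available accounts for the size of this fall. As far as these compounds go, whether it is peculiar to chloro stays open, since fluoro, bromo or an amine at the same place could behave quite differently.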